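The compounds below may be only part of what the source reports. "The series", "measured", "known", "first", "only" and "open" are said of these compounds alone.

Measured compounds:
compound 1 `COc1cccc(-c2csc(N/N=C/c3ccco3)n2)c1` with 6780 nM
compound 2 `COc1cccc(-c2csc(N/N=C(\C)c3cccnc3)n2)c1` with 3.81 nM
compound 3 `COc1cccc(-c2csc(N/N=C/c3c[nH]c4ccccc34)n2)c1` with 800 nM

The three measured compounds share one core and differ only in the group carried on the hydrazone carbon. In an assay on isolated protein for inhibition of Amine oxidase [flavin-containing] B (Homo sapiens), read by fluorescence (a higher number here means a weaker inhibitor, a lower number a stronger inhibitor), compound 2 gives 3.81 nM and stands lowest of the three numbers. The nearest is compound 3, whose value of 800 nM lies well beyond the scatter above it, and the furthest is compound 1 at 6780 nM, further still. Compound 2 is therefore the strongest inhibitor of the set shown, and its number is the one from which compound 4 is judged.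

Compound 4 `CCC/C(C)=N/Nc1nc(-c2cccc(OC)c2)cs1` has not been measured. It differs from compound 2 in one place: propyl in place of pyridin-3-yl on a carbon with a double bond to nitrogen. The change swaps an aromatic ring for a short chain. Among the measured compounds shown here, no measured pair tells what such a swap does here, and no pattern can be read from one compound. Since compound 2 sits so far below the others, the expectation is that the step will be a loss and well beyond the scatter, given as a 39-fold higher number from compound 2 to compound 4 (1.60 log units; beyond the scatter). Compound 4 is thus expected to give about 150 nM in this assay, within a range from 20 nM to 2000 nM.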

Compound 4, half-maximal inhibitory concentration: 871 nM
The estimate for compound 4 lay 5.8-fold (0.76 log units) below the measured number; low and high end bracket the measured number.
By their numbers in this assay, from the lowest: compound 2; then compounds 3 and 4 (each within the scatter of the next); then compound 1.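

In this assay, putting propyl in place of pyridin-3-yl on a carbon with a double bond to nitrogen gives a 230-fold higher number from compound 2 to compound 4 (2.36 log units; beyond the scatter). This is the first direct reading of this position: among these two compounds, the low number belongs to the one carrying the aromatic ring, and the saturated chain carbon on that same carbon, present in both, does not keep it low once pyridin-3-yl has gone. A ring is still not required for some inhibition, as the other step shows a 7.8-fold lower number from compound 1 to compound 4 (0.89 log units; beyond the scatter), where a group with no ring replaces a group holding a five-membered aromatic ring with 1 hetero atom; no measurement at hand explains either step.

From the compounds shown here alone, what remains open is whether the low number of compound 2 rests on the ring nitrogen or on the aromatic ring as such, a question that a phenyl group or a pyridin-4-yl group on the same carbon would address. Also open, going by these compounds, is how a longer chain, or a chain ending in an amine, would compare with propyl.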